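Carbamoyl at a New Place on the Benzoyl

This account rests on a few compounds, and the source may have more. Where it says the series, first, only, none or still open, it means among the compounds named here.

Compound 1 `O=C(c1ccccc1)N1CCC(N(C2CC2)S(=O)(=O)c2cccc(C(F)(F)F)c2)CC1`: 42%
Compound 2 `NC(=O)c1ccccc1C(=O)N1CCC(N(C2CC2)S(=O)(=O)c2cccc(C(F)(F)F)c2)CC1`: 15%
Compound 3 `CS(=O)(=O)c1cccc(C(=O)N2CCC(N(C3CC3)S(=O)(=O)c3cccc(C(F)(F)F)c3)CC2)c1`: 15%

In an assay on HEK293 cells for inhibition of Voltage-dependent N-type calcium channel subunit alpha-1B (Homo sapiens), read by FLIPR and calcium flux, tested at 1 uM (a higher number here means more inhibition at the concentration tested (going by the name of the read-out), a lower number less inhibition), compound 1 stands highest of the three measured compounds, and both others sit the same distance below it: a number 27 percentage points lower from compound 1 to compound 2 (beyond the scatter) and a number 27 percentage points lower from compound 1 to compound 3 (beyond the scatter). Between compound 2 and compound 3 there is no change at the digits printed from compound 2 to compound 3 (within the scatter).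

Compound 4 `NC(=O)c1ccc(C(=O)N2CCC(N(C3CC3)S(=O)(=O)c3cccc(C(F)(F)F)c3)CC2)cc1` differs from compound 1 by carbamoyl in place of hydrogen on an aromatic carbon. For the measured compounds named here, two measured steps bear on this change, both adding a group to the same ring of compound 1, and both gave a modest drop beyond the scatter. A drop of similar size is therefore expected for compound 4, as a number 25 percentage points lower from compound 1 to compound 4 (beyond the scatter). Compound 4 is accordingly estimated to give 17% in this assay, within a range of 2% to 35%.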

Compound 4, a percentage reported as inhibition, at one concentration (the size of the read-out at that concentration, not a potency): 12%
Compound 4: middle estimate off by 5 percentage points, on the high side; low and high end bracket the measured number.
By their numbers in this assay, from the lowest: compounds 4, 2 and 3 (each within the scatter of the next); then compound 1.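

In this assay, carbamoyl on the aromatic carbon para to a large group also lowers the number, with a number 30 percentage points lower from compound 1 to compound 4 (beyond the scatter) as the step from the unsubstituted benzoyl. The step of a number 3 percentage points lower from compound 2 to compound 4 (within the scatter) shows that 4-carbamoylphenyl and 2-carbamoylphenyl are not separated here, and the step of a number 3 percentage points lower from compound 3 to compound 4 (within the scatter) shows the same for 4-carbamoylphenyl and 3-(methylsulfonyl)phenyl. Each of the three substituted benzoyl compounds therefore stands apart from compound 1, but not from one another.

On these data alone, whether an amine, a carboxylic acid or a fluorine at this place would also lower the number stays open. Nothing given accounts for the drop.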